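Chloro for trifluoromethyl on the aryl ring of compound 1

The source may hold more compounds than are shown below. What is called first, only, known or untested is meant among the compounds shown, and "the series" means these compounds.

Among the compounds with values here, compound 1 `Cc1ccc(N2CC(c3nc(-c4cccc(C(F)(F)F)c4)no3)CC2=O)cc1` is the only member of this small set with an actual number: in an in vitro functional assay on HEK293-A cells for positive allosteric modulation of metabotropic glutamate receptor 5 (Homo sapiens), read by FLIPR and calcium flux (a lower number here means that less compound is needed, a higher number that more compound is needed for the effect), compound 1 gives 3400 nM. Compound 2 `O=C1CC(c2nc(-c3ccccn3)no2)CN1c1ccc(F)cc1` reaches only a limit of the assay, > 10000 nM. Compound 3 `O=C1CC(c2nc(-c3cccc(C(F)(F)F)c3)no2)CN1c1ccc(F)cc1` likewise stops at a limit, > 10000 nM. Within the data shown here, the one measured step, an at least 2.9-fold higher number from compound 1 to compound 3 (0.46 log units; beyond the scatter), shows that a fluoro in place of methyl on an aromatic carbon pushes the compound to the limit of > 10000 nM in this assay, at which 2 of the 3 values shown sit, so the series sits close to the edge of what the assay can resolve.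

Compound 4 `Cc1ccc(N2CC(c3nc(-c4cccc(Cl)c4)no3)CC2=O)cc1` differs from compound 1 by chloro in place of trifluoromethyl on an aromatic carbon. Among the measured compounds shown here, no measured step touches this position, so the only guide is that compound 1 itself gives 3400 nM and that the measured step of an at least 2.9-fold higher number from compound 1 to compound 3 (0.46 log units; beyond the scatter) concerns a different ring. Compound 4 is therefore expected to stay near compound 1, with a step of a 1.3-fold higher number from compound 1 to compound 4 (0.12 log units; within the scatter), within the scatter, and an estimated value of 4500 nM (range 1500 nM to 12000 nM).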

Compound 4, half-maximal effective concentration: 630 nM
Compound 4: middle estimate off by 7.1-fold (0.85 log units), on the high side, outside the stated range (below it).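

Within the data shown here, with chloro in place of trifluoromethyl on the aromatic carbon, the number in this assay moves by a 5.4-fold lower number from compound 1 to compound 4 (0.73 log units; beyond the scatter), the first measured step in this set that goes toward less compound being needed. The earlier step concerned the other aromatic ring and ended at a limit, whereas this position gives a change that can be read as a number in both compounds. Compound 2 and compound 3 remain at a limit of the assay, not a number: the limit of > 10000 nM in this assay, at which 2 of the 4 values shown sit.

The compounds shown leave open how a nitrile, a methoxy group or an amine would fare in place of chloro on this ring. They also leave open whether chloro would bring a compound with fluoro in place of methyl on the other ring away from that limit.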